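Shifting the acid substituent in a sphingosine 1-phosphate receptor 2 series

The source may hold more compounds than are shown below. What is called first, only, known or untested is meant among the compounds shown, and "the series" means these compounds.

Measured compounds:
compound 1 `CC(C(=O)O)c1nn(Cc2cn3cc(OCC4CC4)c(C(F)(F)F)cc3n2)c2ccccc2c1=O` gives 56 nM
compound 2 `CC(C)(C(=O)O)c1nn(Cc2cn3cc(OCC4CC4)c(Cl)cc3n2)c2ccccc2c1=O` gives 361 nM
compound 3 `O=C(O)Cn1nc(Cc2cn3cc(OCC4CC4)c(Cl)cc3n2)c2ccccc2c1=O` gives 275 nM

In a functional assay on HFL1 cells for antagonist activity at sphingosine 1-phosphate receptor 2 (Homo sapiens), read by ELISA, with a stated time of 24 h, in the presence of a further agent that is not named here (a higher number here means a weaker inhibitor, a lower number a stronger inhibitor), compound 2 carries the highest number of the three. Compound 3 sits within the usual scatter of it, so no order between compound 2 and compound 3 can be claimed; compound 1 lies beyond the scatter with a lower number, making it the stronger inhibitor of that pair.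

Compound 4 `COC(C(=O)O)c1nn(Cc2cn3cc(OCC4CC4)c(Cl)cc3n2)c2ccccc2c1=O` has not yet been measured. It differs from compound 2 in one place: carboxy(methoxy)methyl in place of 1-carboxy-1-methylethyl on an aromatic carbon. The group that enters keeps the carboxylic acid but trades one of the methyl groups for a methoxy group, on an aromatic carbon next to the ring nitrogen of the shared core.

Going by the values given here, no measured pair isolates this exact change. Compound 2 is the weakest-looking point of the set, and the related acids in compound 1 and compound 3 both give lower numbers, so a modest move toward a stronger inhibitor is expected, though a step within the scatter is also plausible. Compound 4 is estimated at 200 nM in this assay, with a range of 70 nM to 600 nM, which would mean an expected step of a 1.8-fold lower number from compound 2 to compound 4 (0.26 log units; within the scatter).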

Compound 4, half-maximal inhibitory concentration: 217 nM
For compound 4 the middle estimate is 1.1-fold (0.04 log units) below the measured one, and the stated range covers the measured number.
By their numbers in this assay, from the lowest: compound 1; then compounds 4, 3 and 2 (each within the scatter of the next).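

In this assay, the exchange of 1-carboxy-1-methylethyl for carboxy(methoxy)methyl on the aromatic carbon next to the ring nitrogen gives a 1.7-fold lower number from compound 2 to compound 4 (0.22 log units; within the scatter), so the two compounds cannot be placed in any order. Going by these compounds alone, this is the first single-place comparison in the set, and it shows that the two acid groups, each with 6 heavy atoms, cannot be told apart here, although the entering group has one more hydrogen-bond acceptor. Nothing measured here explains this result.

As far as these compounds go, whether a hydroxy group or a longer ethoxy chain in place of the methoxy group would give a step beyond the scatter remains open. Compound 1 differs from compound 4 in more than one place, so the effect of trifluoromethyl in place of chlorine on the shared core also stays unresolved.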